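The source may hold more compounds than are shown below. What is called first, only, known or untested is meant among the compounds shown, and "the series" means these compounds.

In a functional assay on NCI-H460 cells (Homo sapiens) for cytotoxicity, read by MTT assay, with a stated time of 2 days (on this read-out higher numbers stand for weaker inhibition and lower numbers for stronger inhibition), compound 2, whose structure is `Cc1ccc(CO/N=C2/C(c3c[nH]c4ccccc34)=Nc3ccccc32)cc1`, gives 29800 nM. Among the compounds with values here, this is the highest of the three numbers so far. Its nearest neighbour is compound 1, `c1ccc(CO/N=C2/C(c3c[nH]c4ccccc34)=Nc3ccccc32)cc1`, which gives 22000 nM in this assay; the only difference between the two is a 1.4-fold higher number from compound 1 to compound 2 (0.13 log units; within the scatter). Further away stands compound 3, `Clc1cccc(CO/N=C2/C(c3c[nH]c4ccc(Br)cc34)=Nc3ccc(Br)cc32)c1`, which in this assay gives 14600 nM, a gap from compound 2 that lies beyond the scatter; as compound 3 also carries two bromines on the shared core, no single step links it to compound 2.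

Compound 4, `Fc1ccc(CO/N=C2/C(c3c[nH]c4ccccc34)=Nc3ccccc32)c(Cl)c1`, differs from compound 2 by 2-chloro-4-fluorophenyl in place of 4-methylphenyl on a saturated chain carbon bound to an oxygen on an unsaturated carbon. Within the data shown here, the one measured step that bears on this change, from compound 1 to compound 2, altered only the same outer aromatic ring and stayed within the scatter. On that basis the number expected for compound 4 in this assay is close to that of compound 2, with a step of a 1.7-fold lower number from compound 2 to compound 4 (0.22 log units; within the scatter) that is not expected to go beyond the scatter. The estimate for compound 4 is therefore 18000 nM, expected to fall between 8000 nM and 40000 nM.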

Compound 4, half-maximal inhibitory concentration: 21900 nM
Estimate against measurement, compound 4: 1.2-fold (0.09 log units) below; low and high end bracket the measured number.
By their numbers in this assay, from the lowest: compounds 3, 4, 1 and 2 (each within the scatter of the next, the first and the last beyond it).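

In this assay, putting 2-chloro-4-fluorophenyl in place of 4-methylphenyl on a saturated chain carbon bound to an oxygen on an unsaturated carbon gives a 1.4-fold lower number from compound 2 to compound 4 (0.13 log units; within the scatter), and putting the same group in place of phenyl gives a 1.0-fold lower number from compound 1 to compound 4 (0.00 log units; within the scatter). Within the data shown here, the methyl step alone showed only that this outer ring could carry a small carbon group without leaving the scatter; these steps show the same for a ring carrying both a chlorine and a fluorine, so that phenyl, 4-methylphenyl and 2-chloro-4-fluorophenyl all lie within the scatter of one another. Nothing measured here explains why these three rings read alike, and no separate data bear on the result.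

The compounds shown leave open whether an amine or a carboxylic acid on this outer ring, or a longer chain leading to it, would carry the number beyond the scatter. They also leave open how much the bromines on the shared core contribute, as compound 3 differs from the other compounds in more than one place.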